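From trifluoromethoxy to amino: a cytotoxicity note

This account rests on a few compounds, and the source may have more. Where it says the series, first, only, none or still open, it means among the compounds named here.

In an ADME assay on BJ cells (Homo sapiens) for cytotoxicity, with a stated time of 72 h (a lower number here means that less compound is needed, a higher number that more compound is needed for the effect), compound 1 (`Cc1cc(NC(=O)Nc2ccccc2OC(F)(F)F)c2ccccc2n1`) gives > 25000 nM as its result, which is a limit and not a number. Compound 3 (`CSc1ccc(NC(=O)Nc2cc(C)nc3ccccc23)cc1`) gives > 25000 nM in the same read-out, again a limit. Compound 2 (`Cc1cc(NC(=O)Nc2ccc(Cl)c(Cl)c2)c2ccccc2n1`) gives 23000 nM as a measured number and the only one so far. Compound 1 therefore stands with the majority (the limit of > 25000 nM in this assay, at which 2 of the 3 values shown sit) and cannot be ranked more closely.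

Compound 4 (`Cc1cc(NC(=O)Nc2ccccc2N)c2ccccc2n1`) carries amino in place of trifluoromethoxy on an aromatic carbon ortho to a large group. Within the data shown here, no two measured compounds differ in one place only, so the series offers no direct precedent for the size of this change. Among the measured compounds shown here, with compound 2 at 23000 nM as the only number, no large move in either direction is expected. The expected step of an at least 1.2-fold lower number from compound 1 to compound 4 (0.09 log units; that floor lies within the scatter) should stay within the scatter, though a modest fall in the number would not surprise. Compound 4 is expected at 20000 nM with an estimated range from 8000 nM to 40000 nM in this assay when measured.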

Compound 4, half-maximal effective concentration: > 25000 nM
Compound 4 was reported as a limit; the forecaster's own chance of this, stated with the estimate: 55%; at least 1.2-fold (0.09 log units) between middle value and limit.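

Compound 1 and compound 4 are both reported as limits and not as numbers, so no step between them can be read: the limit of > 25000 nM in this assay, at which 3 of the 4 values shown sit.

The compounds shown leave open whether amino in place of trifluoromethoxy on an aromatic carbon changes the number at all in this assay.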